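Swapping a Chlorophenyl for a Pyridyl: Cytotoxicity Outlook

The source may hold more compounds than are shown below. What is called first, only, known or untested is meant among the compounds shown, and "the series" means these compounds.

Measured so far:
Compound 1 `COc1cc(/C=C/c2nc(NCc3ccc(C)cc3)c3sccc3n2)cc(OC)c1OC` gives in an ADME assay on RAW264.7 cells (Mus musculus) for cytotoxicity, read by MTT assay (on this read-out lower numbers stand for stronger inhibition and higher numbers for weaker inhibition), only the assay limit > 50000 nM and no number.
Compound 2 `COc1ccc(CNc2nc(/C=C/c3cc(OC)c(OC)c(OC)c3)nc3ccsc23)cc1` gives in this assay only the assay limit > 50000 nM and no number.
Compound 3 `COc1cc(/C=C/c2nc(NCc3ccc(Cl)cc3)c3sccc3n2)cc(OC)c1OC` gives in this assay only the assay limit > 50000 nM and no number.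

All three compounds share one core and differ only in the group on the benzylic ring. Because every value sits at the same limit (the limit of > 50000 nM in this assay, at which 3 of the 3 values shown sit), none of the steps between them can be sized: the step from compound 1 to compound 2 reads a step that the two limits leave unreadable from compound 1 to compound 2, from compound 1 to compound 3 a step that the two limits leave unreadable from compound 1 to compound 3, and from compound 2 to compound 3 a step that the two limits leave unreadable from compound 2 to compound 3. Compound 3 therefore stands where every measured compound stands, at the limit, with no ranking possible.

Compound 4 `COc1cc(/C=C/c2nc(NCc3ccncc3)c3sccc3n2)cc(OC)c1OC` introduces a new change: pyridin-4-yl in place of 4-chlorophenyl on a saturated chain carbon bound to a nitrogen on an aromatic ring. Among the compounds with values here, no measured step bears on this swap, and the measured steps that exist are themselves unreadable, so nothing indicates a shift in this assay beyond the scatter. The expected step from compound 3 to compound 4 is a step that the limit leaves unreadable from compound 3 to compound 4. For compound 4 the estimate is 60000 nM, within 30000 nM to 200000 nM, most likely again reported as a limit.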

Compound 4, half-maximal inhibitory concentration: > 50000 nM
Compound 4 ended at the assay's limit; the forecaster's own chance of this, stated with the estimate: 85%; the middle value lies beyond the limit too.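

In this assay, within the data shown here, no step to compound 4 from compound 1, compound 2 or compound 3 can be read, because each compound gives only a limit and no number: the limit of > 50000 nM in this assay, at which 4 of the 4 values shown sit. The compounds shown leave open whether the 4-methylphenyl, 4-methoxyphenyl, 4-chlorophenyl and pyridin-4-yl versions differ at all in this assay, and what change would bring a measurable number.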